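The compounds below may be only part of what the source reports. "The series", "measured", "known", "first", "only" and "open" are said of these compounds alone.

Of the compounds shown here, three built on one shared core have been measured in an ADME assay on MRC5 cells (Homo sapiens) for inhibition, with a stated time of 72 h (on this read-out lower numbers stand for an effect already at smaller amounts and higher numbers for an effect only at larger amounts of compound), and a fourth now awaits the same test. Compound 1 `COCCNC(=O)c1n[nH]cc1NC(=O)c1c(OC)cccc1OC` reached only the limit of the assay, > 50000 nM. Compound 2 `COc1cccc(OC)c1C(=O)Nc1c[nH]nc1C(=O)NN1CCOCC1` likewise stopped at a limit, > 50000 nM. Going by the values given here, compound 3 `COc1cccc(OC)c1C(=O)Nc1c[nH]nc1C(=O)NCc1ccccc1` is the only member with an actual number, giving 50000 nM in this assay. Compounds 1 and 2 sit at the limit of > 50000 nM in this assay, at which 2 of the 3 values shown sit. Among the compounds with values here, the step that the two limits leave unreadable from compound 1 to compound 2 cannot be read at all, while a number no higher from compound 1 to compound 3 (the limit leaves the size open) and a number no higher from compound 2 to compound 3 (the limit leaves the size open) show only that compound 3 lies no higher than the other two, their sizes left open.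

Compound 4 `COC(=O)c1n[nH]cc1NC(=O)c1c(OC)cccc1OC` differs from compound 3 by methoxy in place of benzylamino on a carbonyl carbon. Within the data shown here, none of the measured steps concerns a change on the carbonyl carbon; all three alter the group on the amide-type nitrogen, and none of them yields a readable size. Among the measured compounds shown here, there is thus no measured step from which a direction or magnitude for this change could be taken. With every value at or against the limit, compound 4 is expected to show no step beyond the scatter, and no change at the digits printed from compound 3 to compound 4 (within the scatter) is estimated as essentially flat. Compound 4 is therefore estimated at 50000 nM in this assay, between 25000 nM and 100000 nM, with a considerable chance that only a limit is reported.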

Compound 4, half-maximal effective concentration: > 50000 nM
Compound 4 ended at the assay's limit; the forecaster's own chance of this, stated with the estimate: 60%; the middle value sits exactly at the limit.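

Going by these compounds alone, replacing benzylamino with methoxy on a carbonyl carbon, a change that no earlier step touched, gives in this assay a number no lower from compound 3 to compound 4 (the limit leaves the size open). Compound 4 gives > 50000 nM, which is a limit of the assay and not a number. The steps from compound 1 and from compound 2 to compound 4 cannot be read, so compound 3 remains the only member with an actual number, and the change at this position adds one more compound to those held at the limit: the limit of > 50000 nM in this assay, at which 3 of the 4 values shown sit.

From the compounds shown here alone, how far compound 4 lies from compound 3 stays open, so neither the size of this change nor whether it exceeds the usual scatter can be told. The compounds shown also leave open what a carboxylic acid or a primary amide at this carbonyl carbon, or a longer chain in place of methoxy, would give in this assay.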